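Pyridin-2-yl for phenyl in the compound 1 series

The source may hold more compounds than are shown below. What is called first, only, known or untested is meant among the compounds shown, and "the series" means these compounds.

Measured so far in an ADME assay on CCRF-CEM cells (Homo sapiens) for cytotoxicity, read by MTT assay, with a stated time of 72 h (a higher number here means that more compound is tolerated, a lower number that less compound is tolerated), as half-maximal cytotoxic concentration
- compound 1 `CC(C)CC(=O)c1c(O)c(C(=O)CC(C)C)c(O)c(C(c2ccccc2)c2c(O)c(C(=O)CC(C)C)c(O)c(C(=O)CC(C)C)c2O)c1O` gives 3150 nM
- compound 2 `CC(C)CC(=O)c1c(O)c(C(=O)CC(C)C)c(O)c(C(c2ccc(OCc3ccccc3)cc2)c2c(O)c(C(=O)CC(C)C)c(O)c(C(=O)CC(C)C)c2O)c1O` gives 24000 nM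
- compound 3 `CC(=O)c1c(O)c(C(C)=O)c(O)c(C(c2ccc(N(C)C)cc2)c2c(O)c(C(C)=O)c(O)c(C(C)=O)c2O)c1O` gives 22100 nM

Not yet measured
- compound 4 `CC(C)CC(=O)c1c(O)c(C(=O)CC(C)C)c(O)c(C(c2ccccn2)c2c(O)c(C(=O)CC(C)C)c(O)c(C(=O)CC(C)C)c2O)c1O`

Compound 1 has the lowest of the three numbers (3150 nM), and both compound 2 and compound 3 lie clearly higher. Going by the values given here, the change under review is pyridin-2-yl in place of phenyl on a saturated chain carbon bound to two aromatic carbons and no measured step exchanges phenyl for another ring.

Among the compounds with values here, the only measured step that changes a single place is a 7.6-fold higher number from compound 1 to compound 2 (0.88 log units; beyond the scatter) with benzyloxy in place of hydrogen on an aromatic carbon. That step adds a group to the same phenyl, so it bears on compound 4 only loosely. Compound 3 differs from compound 1 in more than one place and offers no clean comparison.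

A step well short of a 7.6-fold higher number from compound 1 to compound 2 (0.88 log units; beyond the scatter) is therefore expected in this assay and the direction, if any, is weakly upward, since compound 1 sits at the low end of the data. The expected step is a 1.4-fold higher number from compound 1 to compound 4 (0.15 log units; within the scatter) and the data cannot firmly separate it from no change. In this assay the estimated value for compound 4 is 4500 nM within an expected range of 2000 nM to 12000 nM overall.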

Compound 4, half-maximal cytotoxic concentration: 38100 nM
For compound 4 the middle estimate is 8.5-fold (0.93 log units) below the measured one; the whole stated range lies below it.
By their numbers in this assay, from the lowest: compound 1; then compounds 3, 2 and 4 (each within the scatter of the next).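

In this assay, a 12-fold higher number from compound 1 to compound 4 (1.08 log units; beyond the scatter) shows that this place is sensitive to a change in the ring itself: pyridin-2-yl replaces phenyl on a saturated chain carbon bound to two aromatic carbons, the heavy-atom count stays at 6, and one ring carbon gives way to nitrogen, adding 1 hydrogen-bond acceptor. Until now the only single-place step at this ring was the addition of benzyloxy, a 7.6-fold higher number from compound 1 to compound 2 (0.88 log units; beyond the scatter), so a large rise in the tolerated concentration can now be seen without any added bulk, and both single-place departures from compound 1 raise the number, leaving the plain phenyl of compound 1 lowest among these compounds. Nothing available on these compounds gives a reason for the step, so the result stands as an observation only.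

From the compounds shown here alone, whether the gain is tied to the pyridin-2-yl ring or also extends to other heteroaromatic rings at this place, such as pyrimidinyl or thienyl, remains open. Also open, going by these compounds, is whether a carboxylic acid or an amine on the phenyl ring would move the number in the same direction.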